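The compounds below may be only part of what the source reports. "The series", "measured", "known", "first", "only" and "open" are said of these compounds alone.

Measured so far in a functional assay on MCF7 cells (Homo sapiens) for inhibition, read by MTT assay, with a stated time of 48 h; a lower number here means a stronger inhibitor, a higher number a weaker inhibitor:

- Compound 1 `CCOC(=O)C1=C(N/N=C(/Br)c2ccccc2)Nc2[nH]nc(C)c2C1c1ccc(N(C)C)cc1`: 78400 nM
- Compound 2 `CCOC(=O)C1=C(N/C=N/c2ccccn2)Nc2[nH]nc(C)c2C1c1ccc(N(C)C)cc1`: 37300 nM
- Compound 3 `CCOC(=O)C1=C(N/N=C(/Cl)C#N)Nc2[nH]nc(C)c2C1c1ccc(N(C)C)cc1`: 23200 nM

Compound 3 gives 23200 nM and shares the low end of this small range with compound 2. The data show a 1.6-fold lower number from compound 2 to compound 3 (0.21 log units; within the scatter), against a clearer a 3.4-fold lower number from compound 1 to compound 3 (0.53 log units; beyond the scatter).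

The next compound is compound 4 `CCOC(=O)C1=C(N/N=C(/C(=O)Br)c2ccc(Cl)cc2)Nc2[nH]nc(C)c2C1c1ccc(N(C)C)cc1`, which keeps the shared core and changes only the group on the amine nitrogen: a group of 12 heavy atoms (8 carbon, 1 nitrogen, 1 oxygen, 1 chlorine, 1 bromine; one six-membered aromatic ring of carbon only) in place of a group of 5 heavy atoms (2 carbon, 2 nitrogen, 1 chlorine; no ring), on an amine nitrogen. The incoming group holds one six-membered aromatic ring of carbon only, and so does the group of compound 1. That makes compound 1 the closest guide, and read in reverse, the measured 3.4-fold lower number from compound 1 to compound 3 (0.53 log units; beyond the scatter) suggests that such a group could bring a higher number. Compound 2 tempers this, since its group also holds a six-membered aromatic ring, with 1 hetero atom, yet it shows a 1.6-fold lower number from compound 2 to compound 3 (0.21 log units; within the scatter). The smaller 2.1-fold lower number from compound 1 to compound 2 (0.32 log units; beyond the scatter) also shows that the two ring-bearing groups differ from each other. Going by the values given here, no measured compound carries the exact incoming group.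

A modest move towards a higher number in this assay is therefore expected, estimated as a 2.2-fold higher number from compound 3 to compound 4 (0.33 log units; beyond the scatter). For compound 4 the estimated value is 50000 nM, with an expected range from 20000 nM to 120000 nM.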

Compound 4, half-maximal inhibitory concentration: 46300 nM
Estimate against measurement, compound 4: 1.1-fold (0.03 log units) above; measured number inside the range.
By their numbers in this assay, from the lowest: compounds 3, 2, 4 and 1 (each within the scatter of the next, the first and the last beyond it).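

In this assay, the group of 12 heavy atoms on the amine nitrogen gives a 2.0-fold higher number from compound 3 to compound 4 (0.30 log units; within the scatter), so this larger group with one six-membered aromatic ring of carbon only is not separated from the ring-free group of 5 heavy atoms. It is also not separated from either ring-bearing group: the data show a 1.2-fold higher number from compound 2 to compound 4 (0.09 log units; within the scatter) against the ring with 1 hetero atom, and a 1.7-fold lower number from compound 1 to compound 4 (0.23 log units; within the scatter) against the other ring of carbon only. A carbon-only ring at this position therefore does not by itself go with the clear gap seen in a 3.4-fold lower number from compound 1 to compound 3 (0.53 log units; beyond the scatter), which is the only step among these four compounds that remains beyond the scatter.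

The compounds shown leave open whether the chlorine or the carbonyl in the incoming group contributes anything, since the group changes as a whole. They also leave open whether an amine or a carboxylic acid on this nitrogen would move the number outside this narrow band. No supporting data are available to explain these results.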